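From 1-carboxy-2-hydroxypropyl to 1-carboxy-2-hydroxyethyl on an amine nitrogen

The compounds below may be only part of what the source reports. "The series", "measured", "known", "first", "only" and "open" are said of these compounds alone.

Measured in an ADME assay on KB cells (Homo sapiens) for cytotoxicity, with a stated time of 48 h; on this read-out lower numbers stand for stronger inhibition and higher numbers for weaker inhibition:
Compound 1 `C=C1[C@H](C)CCC[C@]1(C)CC/C(C)=C/CC1=C(O)C(=O)C=C(N[C@@H](C(=O)O)C(C)C)C1=O`: 6.2 ug/mL
Compound 2 `C=C1[C@H](C)CCC[C@]1(C)CC/C(C)=C/CC1=C(O)C(=O)C=C(N[C@H](C(=O)O)[C@@H](C)O)C1=O`: > 10 ug/mL, a limit and not a number

Compound 2 has only a limit to its name, and it stands at the limit of > 10 ug/mL in this assay, at which 1 of the 2 values shown sits. Compound 3 `C=C1[C@H](C)CCC[C@]1(C)CC/C(C)=C/CC1=C(O)C(=O)C=C(N[C@H](CO)C(=O)O)C1=O` differs from compound 2 in one place, with 1-carboxy-2-hydroxyethyl in place of 1-carboxy-2-hydroxypropyl on an amine nitrogen. Going by the values given here, the only measured step that bears on this change is an at least 1.6-fold higher number from compound 1 to compound 2 (0.20 log units; that floor lies within the scatter), which alters the group at the same nitrogen. That step gives a floor and not a full size, so it offers no measured guide to a further move. No step beyond the scatter is therefore expected in this assay, in either direction. The expected step is a step that the limit leaves unreadable from compound 2 to compound 3. Compound 3 is estimated at 12 ug/mL, with an expected range of 6 ug/mL to 25 ug/mL.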

Compound 3, half-maximal inhibitory concentration: > 10 ug/mL
Compound 3: only a limit was reported; the forecaster's own chance of this, stated with the estimate: 65%; the middle value is on the limit's open side.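

In this assay compound 3 gives > 10 ug/mL, which is a limit and not a number. The step between compound 2 and compound 3 cannot be read, while hydroxymethyl in place of isopropyl on the saturated chain carbon bound to the amine nitrogen and a carbonyl carbon gives an at least 1.6-fold higher number from compound 1 to compound 3 (0.20 log units; that floor lies within the scatter). Removing the methyl from the 1-carboxy-2-hydroxypropyl group therefore brings no readable number, and compound 2 and compound 3 share one limit: the limit of > 10 ug/mL in this assay, at which 2 of the 3 values shown sit.

On these data alone, how far compound 2 and compound 3 lie past that limit stays open, as does whether they differ at all. Also open, as far as these compounds go, is how the read-out responds to a longer chain such as isobutyl, or to a benzyl group, in place of isopropyl on that saturated chain carbon.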